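The source may hold more compounds than are shown below. What is called first, only, known or untested is meant among the compounds shown, and "the series" means these compounds.

Measured in an assay on lysate for inhibition of phosphatidylcholine:ceramide cholinephosphotransferase 2 (Homo sapiens), read by HPLC, with stated times of 30 min and 2 h; a higher number here means a weaker inhibitor, a lower number a stronger inhibitor:
compound 1, `O=C(NCc1ccco1)c1ccccc1OCc1ccccc1`: 49000 nM
compound 2, `O=C(NC1CCCNC1)c1ccccc1OCc1ccccc1Cl`: value is an assay limit, > 100000 nM
compound 3, `O=C(Nc1cccnc1)c1ccccc1OCc1ccccc1Cl`: 1100 nM

Compound 3 holds the lowest of the two numbers in this assay; compound 1 stands far higher. Compound 2 sits at a limit of the assay (the limit of > 100000 nM in this assay, at which 1 of the 3 values shown sits). Among the measured compounds shown here, the one measured step, an at least 90-fold lower number from compound 2 to compound 3 (1.95 log units; beyond the scatter), is a large one and concerns the group on the amide-type nitrogen only.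

Compound 4, `O=C(Nc1cccnc1)c1ccccc1OCc1cc(F)ccc1Cl`, differs from compound 3 by fluoro in place of hydrogen on an aromatic carbon. No measured step touches the benzyl ring, so nothing shown bears on this change. For compound 4 a step no larger than the scatter is expected, no change at the digits printed from compound 3 to compound 4 (within the scatter), with no direction favoured. Compound 4 is therefore estimated at 1100 nM, between 350 nM and 3500 nM.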

Compound 4, half-maximal inhibitory concentration: 740 nM
Compound 4: the middle estimate sits 1.5-fold (0.17 log units) above what was measured; the measured number falls inside the stated range.
By their numbers in this assay, from the lowest: compounds 4 and 3 (each within the scatter of the next); then compound 1. At a limit, above all of these: compound 2.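

In this assay, among the compounds shown here, the change from 2-chlorophenyl to 2-chloro-5-fluorophenyl gives a 1.5-fold lower number from compound 3 to compound 4 (0.17 log units; within the scatter) and is the first reading at this position, which the earlier compounds all held at hydrogen. This position therefore carries a fluoro group, para to the chloro group, with no shift beyond the scatter. Nothing at hand accounts for the size of this step.

Still open, from the compounds shown here alone, is whether methoxy, trifluoromethyl or an amine at this position would move the number beyond the scatter. Also open, going by these compounds, is what hydrogen in place of the chloro group would do with the pyridin-3-yl group kept on the amide nitrogen.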